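Bis-indolyl acrylonitriles: fluoro to methoxy exchanges

The compounds below may be only part of what the source reports. "The series", "measured", "known", "first", "only" and "open" are said of these compounds alone.

Compound 1 `N#C/C(=C\c1c[nH]c2cc(F)ccc12)C(=O)c1c[nH]c2cc(F)ccc12` carries fluoro on both of its indole rings. In a functional assay on MIA PaCa-2 cells (Homo sapiens) for cytotoxicity, read by WST assay, with a stated time of 24 h (a lower number here means a stronger inhibitor, a higher number a weaker inhibitor), compound 1 reaches only the limit of the assay, > 50000 nM. Compound 2 `COc1ccc2[nH]cc(/C=C(\C#N)C(=O)c3c[nH]c4cc(F)ccc34)c2c1` differs from compound 1 in more than one place; how the two cores differ is not broken down here. In this assay compound 2 also stops at the limit, > 50000 nM. Compound 3 `COc1ccc2c(C(=O)/C(C#N)=C/c3c[nH]c4cc(F)ccc34)c[nH]c2c1` arises from compound 1 by methoxy in place of fluoro on an aromatic carbon. In this assay compound 3 gives the limit > 50000 nM as well. The step that the two limits leave unreadable from compound 1 to compound 3 therefore cannot be read, since both ends are limits; this rests on (the limit of > 50000 nM in this assay, at which 3 of the 3 values shown sit).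

Compound 4 `COc1ccc2c(C(=O)/C(C#N)=C/c3c[nH]c4ccc(OC)cc34)c[nH]c2c1` is not yet measured. It arises from compound 2 by methoxy in place of fluoro on an aromatic carbon, the same change as from compound 1 to compound 3, at a place described in the same words. Because the earlier step that the two limits leave unreadable from compound 1 to compound 3 sits between two limits, no size can be carried over, and all three measured values sit at the same limit (the limit of > 50000 nM in this assay, at which 3 of the 3 values shown sit). The step that the limit leaves unreadable from compound 2 to compound 4 is accordingly expected to be unreadable in the same way, with compound 4 expected to remain at the limit. The estimate for compound 4 in this assay is 60000 nM, with a range from 25000 nM to 200000 nM, and the most likely outcome is again a limit rather than a number.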

Compound 4, half-maximal inhibitory concentration: > 50000 nM
Compound 4: a limit, no number; the forecaster's own chance of this, stated with the estimate: 85%; the middle value does not contradict the limit.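

In this assay compound 4 gives > 50000 nM, a limit and not a number. The exchange of fluoro for methoxy from compound 2 to compound 4 gives no readable step, since both ends are limits: the limit of > 50000 nM in this assay, at which 4 of the 4 values shown sit.

The compounds shown leave open whether methoxy in place of fluoro changes cytotoxicity at all, and what structural change would bring a value within the range of this assay.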